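The source may hold more compounds than are shown below. What is called first, only, known or untested is meant among the compounds shown, and "the series" means these compounds.

Working notes. Compound 1 `COc1cc(-c2nn(-c3cccc(NC(=O)c4ccc(Cl)c(C(F)(F)F)c4)c3)cc2-c2ccncc2)ccc1Cl` is followed in a functional assay on HOP-92 cells (Homo sapiens) for inhibition, read by sulforhodamine B assay, with a stated time of 48 h; a higher number here means that more compound is tolerated, a lower number that less compound is tolerated. In this assay compound 1 gives > 32500 nM, which is a limit of the assay and not a number. Compound 2 `O=C(Nc1cccc(-n2cc(-c3ccncc3)c(-c3ccc(Cl)c(O)c3)n2)c1)Nc1cccc(C(F)(F)F)c1` gives > 32500 nM in this assay, again a limit and not a number. Both compounds sit at the limit of > 32500 nM in this assay, at which 2 of the 2 values shown sit. Compound 3 `COc1cc(-c2nn(-c3cccc(NC(=O)Nc4ccc(Cl)c(Cl)c4)c3)cc2-c2ccncc2)ccc1Cl` remains to be measured in this assay; it differs from compound 1 by (3,4-dichlorophenyl)amino in place of 4-chloro-3-(trifluoromethyl)phenyl on a carbonyl carbon. Going by the values given here, no measured step informs this change, and no step beyond the scatter is expected, the estimated step being a step that the limit leaves unreadable from compound 1 to compound 3. Compound 3 is expected to give 40000 nM, in the range 15000 nM to 100000 nM, most likely again only a limit.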

Compound 3, concentration lethal to 50% of the cells: > 50000 nM
Compound 3 gave a limit, no number; the forecaster's own chance of this, stated with the estimate: 85%; middle value at least 1.2-fold (0.09 log units) from the limit.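

Going by these compounds alone, compound 1 and compound 3 both stand as limits and not numbers in this assay, and no step between them can be read. The compounds shown leave open whether any step at all comes with (3,4-dichlorophenyl)amino in place of 4-chloro-3-(trifluoromethyl)phenyl.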